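Methoxy in place of trifluoromethyl: notes on compound 3

This account rests on a few compounds, and the source may have more. Where it says the series, first, only, none or still open, it means among the compounds named here.

For the measured compounds named here, in a functional assay on KG-1 cells (Homo sapiens) for cytotoxicity, read by luminescence and CellTiter-Glo, with a stated time of 3 days (on this read-out higher numbers stand for weaker inhibition and lower numbers for stronger inhibition), compound 2 (`N#Cc1ccc(NC(=O)c2ccc(C(F)(F)F)cc2O)cc1`) gives 1440 nM and compound 1 (`Cc1ccc(C(=O)Nc2ccc(C#N)cc2)c(O)c1`) gives 2560 nM as the only other number so far. The two sit within the scatter of each other, so compound 2 holds no clear rank. Compound 3 (`COc1ccc(C(=O)Nc2ccc(C#N)cc2)c(O)c1`) carries methoxy in place of trifluoromethyl on an aromatic carbon, meta to a hydroxy group and para to a large group (methoxy in place of trifluoromethyl on an aromatic carbon). Going by the values given here, the one measured step at this place is trifluoromethyl in place of methyl (a 1.8-fold lower number from compound 1 to compound 2 (0.25 log units; within the scatter)) and it stays within the scatter. Methoxy itself is unmeasured there, so this step gives thin support, and no step beyond the scatter is expected in this assay on this evidence. The estimated step is small (a 1.5-fold higher number from compound 2 to compound 3 (0.18 log units; within the scatter)) and its direction is uncertain. For compound 3 the expected value is 2200 nM with an estimated range of 800 nM to 5500 nM on this basis.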

Compound 3, half-maximal inhibitory concentration: 5430 nM
Beside the measured number, compound 3's estimate is 2.5-fold (0.39 log units) below it; the range from low to high includes it.
By their numbers in this assay, from the lowest: compounds 2 and 1 (each within the scatter of the next); then compound 3.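

This position is not indifferent to the group it carries: trifluoromethyl and methyl could not be told apart here, but in this assay methoxy separates from both, in place of trifluoromethyl (a 3.8-fold higher number from compound 2 to compound 3 (0.58 log units; beyond the scatter)) and in place of methyl (a 2.1-fold higher number from compound 1 to compound 3 (0.33 log units; beyond the scatter)). Both steps run the same way and both are modest, so among these three groups only methoxy stands apart, with compound 3 giving the highest number of the series. No measurement on hand accounts for this shift.

The compounds shown leave open whether the higher number is particular to methoxy or would also follow other groups at this place, such as an amine, a carboxylic acid or a longer ether chain like ethoxy. They also leave open whether the same change would give a similar step on another core.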